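A few compounds are considered here, and "the series" means these few. Any claim that something is new, unique, unknown or untested is made for them only; others in the source may bear on it.

Measured compounds:
- compound 1, `O=C(Nc1ccc(Sc2nc3ccccc3s2)c(Cl)c1)c1cccc(Br)c1O`, in an assay for inhibition of HSP60/HSP10 (Homo sapiens), with a stated time of 60 min (on this read-out higher numbers stand for weaker inhibition and lower numbers for stronger inhibition), gives 6900 nM
- compound 2, `O=C(Nc1ccc(Sc2nc3ccccc3s2)c(Cl)c1)c1cc(Br)cc(Br)c1O`, in this assay gives 4200 nM
- compound 3, `COc1c(Br)cccc1C(=O)Nc1ccc(Sc2nc3ccccc3s2)c(Cl)c1`, in this assay gives > 100000 nM, which is a limit of the assay and not a number.

Compound 3 thus stands at the weak end of the three, with nothing known for it beyond the limit (the limit of > 100000 nM in this assay, at which 1 of the 3 values shown sits). Compound 4, `COc1ccc(Br)cc1C(=O)Nc1ccc(Sc2nc3ccccc3s2)c(Cl)c1`, differs from compound 3 in that (a group of 9 heavy atoms (7 carbon, 1 oxygen, 1 bromine; one six-membered aromatic ring of carbon only) in place of a group of 9 heavy atoms (7 carbon, 1 oxygen, 1 bromine; one six-membered aromatic ring of carbon only), on a carbonyl carbon). The same atoms are present in both, joined differently: the methoxy group stays, only the bromine sits elsewhere on the ring.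

Going by the values given here, two measured steps bear on this. The step of an at least 14-fold higher number from compound 1 to compound 3 (1.16 log units; beyond the scatter) shows that putting methyl on the phenolic oxygen took the number from a measurable value to the limit, and the step of an at least 23-fold higher number from compound 2 to compound 3 (1.37 log units; beyond the scatter) is likewise large. The step of a 1.6-fold lower number from compound 1 to compound 2 (0.22 log units; within the scatter) lies within the scatter, so a second bromine on the hydroxy-bearing ring is not resolved. Compound 4 keeps the methoxy that both large steps point to. The step from compound 3 to compound 4 is therefore expected to be none beyond the scatter, a number no higher from compound 3 to compound 4 (the limit leaves the size open). Compound 4 is expected at about 100000 nM, between 30000 nM and 300000 nM, and a limit rather than a number is expected to be reported again.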

Compound 4, half-maximal inhibitory concentration: > 100000 nM
Compound 4: a limit, no number; the forecaster's own chance of this, stated with the estimate: 70%; the middle value sits exactly at the limit.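

Replacing the hydroxy-bearing ring with the 5-bromo-2-methoxyphenyl group on the carbonyl carbon gives an at least 14-fold higher number from compound 1 to compound 4 (1.16 log units; beyond the scatter) and an at least 23-fold higher number from compound 2 to compound 4 (1.37 log units; beyond the scatter), so the large gap to the hydroxy compounds also holds for a methoxy compound with its bromine placed differently from that of compound 3. In this assay compound 4 gives > 100000 nM, which is a limit of the assay and not a number, so this bromine placement on the methoxy-bearing ring does not return a measurable value. The step between compound 3 and compound 4 cannot be read, and the two methoxy compounds now share one limit: the limit of > 100000 nM in this assay, at which 2 of the 4 values shown sit.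

On these data alone, how far either methoxy compound lies past that limit remains open, and with it any difference between the two bromine placements. Also open, as far as these compounds go, is whether a measurable value needs the free hydroxy group itself, or whether an amine or a carboxylic acid in its place on the ring would also give one.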